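This account rests on a few compounds, and the source may have more. Where it says the series, first, only, none or still open, it means among the compounds named here.

Going by the values given here, compound 2 `Clc1ccc(Cl)c(-c2nc(N3CCCCC3)c3nc[nH]c3n2)c1` is the weaker of the two compounds measured so far. In an assay on cells for displacement of a labelled ligand from adenosine receptor A3 (Homo sapiens), read by scintillation counting and radioligand binding, with a stated time of 180 min (on this read-out higher numbers stand for weaker inhibition and lower numbers for stronger inhibition), compound 2 gives 200 nM, the higher of the two numbers, while compound 1 `Oc1cccc(-c2nc(N3CCCCC3)c3nc[nH]c3n2)c1` gives 63.1 nM in this assay, a gap that lies beyond the usual scatter. The two compounds differ in more than one place, so nothing more can be read from that pair than the two values themselves.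

Compound 3 `Clc1cccc(-c2nc(N3CCCCC3)c3nc[nH]c3n2)c1` has not yet been measured. It differs from compound 2 in one place: hydrogen in place of chloro on an aromatic carbon, the change sitting on an aromatic carbon of a six-membered aromatic ring of carbon only, ortho to a large group and para to a chloro group. Among the compounds with values here, since no measured pair shows this exact step, its size can only be expected, not derived. The writer expects the number for compound 3 to come out lower than that of compound 2 in this assay, a moderate step of a 2.5-fold lower number from compound 2 to compound 3 (0.40 log units; beyond the scatter), because compound 1 with a single small group on the same ring gives 63.1 nM. The estimate for compound 3 is therefore 80 nM, with a range from 25 nM to 250 nM.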

Compound 3, inhibition constant: 39.8 nM
Compound 3: the middle estimate sits 2.0-fold (0.30 log units) above what was measured; the range from low to high includes it.
By their numbers in this assay, from the lowest: compounds 3 and 1 (each within the scatter of the next); then compound 2.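

In this assay, going by these compounds alone, replacing the chloro that sits ortho to a large group and para to a chloro group with hydrogen gives a 5.0-fold lower number from compound 2 to compound 3 (0.70 log units; beyond the scatter), the first single change that can be read directly, and it ties the weaker inhibition of compound 2 to that one chloro on the ring. Within the data shown here, the other substituent on the ring behaves differently: exchanging hydroxy for chloro on its aromatic carbon gives a 1.6-fold lower number from compound 1 to compound 3 (0.20 log units; within the scatter), so at that place the two groups cannot be told apart in this read-out, and the single chloro of compound 3 keeps inhibition in the same range as the hydroxy of compound 1. Nothing measured here accounts for either result.

The compounds shown leave open whether a fluoro or a methyl group on the aromatic carbon that held the departing chloro would match hydrogen or chloro, and so whether the step belongs to chloro alone or to any group at that place. They also leave open what an amine would do in place of the remaining chloro or the hydroxy, and whether a ring carrying only hydrogen would read the same.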